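Plasma protein binding from compound 2 to compound 3

The source may hold more compounds than are shown below. What is called first, only, known or untested is meant among the compounds shown, and "the series" means these compounds.

Measured so far:
compound 1 `CCN1CC(c2nc(C(=O)NCc3ccc(F)cc3)c(O)c3ncccc23)CC1=O` gives 98.9%
compound 2 `CC(C)N1CC(c2nc(C(=O)NCc3ccc(F)cc3)c(O)c3ncccc23)CC1=O` gives 97.8%

For the measured compounds named here, compound 1 at 98.9% and compound 2 at 97.8% lie within the scatter of each other in an ADME assay on a cell-free system (plasma, Homo sapiens) for protein binding, at pH 7.4, so compound 2 stands level with its only measured neighbour. The next compound is compound 3 `CN(C)C(=O)CN1CC(c2nc(C(=O)NCc3ccc(F)cc3)c(O)c3ncccc23)CC1=O` and the change (dimethylcarbamoyl)methyl in place of isopropyl on an amide-type nitrogen in a ring puts (dimethylcarbamoyl)methyl in place of isopropyl on an amide-type nitrogen in a ring. Going by the values given here, only one measured step bears on this, namely a 2.0-fold higher unbound fraction from compound 1 to compound 2 (0.30 log units; within the scatter) for methyl in place of hydrogen on a saturated chain carbon bound to that kind of nitrogen. That step stays within the scatter and involves a much smaller swap, so it is a weak guide. In this assay the expected step of a 1.8-fold higher unbound fraction from compound 2 to compound 3 (0.26 log units; within the scatter) is modest and points towards more free compound. Compound 3 is estimated at 96% with an expected range from 90% to 98.5% on this read-out.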

Compound 3, plasma protein binding in the plasma assay: 94.8%
Estimate against measurement, compound 3: 1.3-fold (0.11 log units) (unbound fraction) below; low and high end bracket the measured number.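

In the plasma assay, (dimethylcarbamoyl)methyl in place of isopropyl on an amide-type nitrogen in a ring gives a 2.4-fold higher unbound fraction from compound 2 to compound 3 (0.37 log units; beyond the scatter), and the comparison with the smaller group gives a 4.7-fold higher unbound fraction from compound 1 to compound 3 (0.67 log units; beyond the scatter). Both steps lie beyond the scatter, so this position does respond on this read-out to a large enough change, which the earlier step within the scatter could not show. In a physicochemical assay for lipophilicity, at pH 7.4 (a lower number here means a more polar compound, a higher number a more lipophilic compound), compound 2 gives 2.7 and compound 3 gives 1.8. The higher unbound fraction comes with lower lipophilicity in the physicochemical assay, which may be why less of compound 3 is bound: the measured partition coefficient of compound 2, 2.7, and of compound 3, 1.8, a number 0.90 log units lower (beyond the scatter)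

On these data alone, whether the shift belongs to the dimethylcarbamoyl group itself or would also appear with an amine or a carboxylic acid on this chain stays open. How far lipophilicity alone sets the binding at this position also remains unsettled by these compounds.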